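The compounds below may be only part of what the source reports. "The series", "measured", "known", "first", "only" and "open" are said of these compounds alone.

Measured so far in an assay on isolated protein for inhibition of matrix metalloproteinase-9 (Homo sapiens); on this read-out higher numbers stand for weaker inhibition and lower numbers for stronger inhibition:
Compound 1, `C=C[C@@H]1OC(c2ccc(Br)cc2)=N[C@H]1SC(C)=O`, gives 88000 nM.
Compound 2, `C=C[C@@H]1OC(c2ccc(-c3ccccc3)cc2)=N[C@H]1Sc1ccccc1`, gives only a limit of the assay, > 100000 nM.
Compound 3, `C=C[C@@H]1OC(/C=C/c2ccc(Br)cc2)=N[C@H]1CO`, gives 22000 nM.

Of the two true numbers, compound 1 holds the higher one, so its inhibition is the weaker of the two, and compound 3 sits lower by a gap that goes beyond the usual scatter. Compound 2 reaches only (the limit of > 100000 nM in this assay, at which 1 of the 3 values shown sits), so for it nothing more than a limit is known. The compound of interest, compound 4, is `C=C[C@@H]1OC(c2ccc(Br)cc2)=N[C@H]1CO`. Compared with compound 1 the change is hydroxymethyl in place of acetylsulfanyl on a saturated ring carbon. Going by the values given here, no pair of measured compounds isolates this change, so its size can only be estimated. The same hydroxymethyl group appears in compound 3, whose value of 22000 nM is the lower of the two numbers, though there the core carries a different group. The expected step is a 2.2-fold lower number from compound 1 to compound 4 (0.34 log units; beyond the scatter), in the direction of stronger inhibition, and it may stay within the scatter. For compound 4 the estimate in this assay is 40000 nM, with a range from 12000 nM to 130000 nM.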

Compound 4, inhibition constant: 9000 nM
Compound 4: middle estimate off by 4.4-fold (0.65 log units), on the high side; measured number below the stated range.
By their numbers in this assay, from the lowest: compound 4; then compound 3; then compound 1. At a limit, above all of these: compound 2.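

In this assay, going by these compounds alone, compounds 1 and 4 form the first pair that differs in one place, so a 9.8-fold lower number from compound 1 to compound 4 (0.99 log units; beyond the scatter) gives a direct reading of what the group on this saturated ring carbon, next to the ring nitrogen, does to the number. Before this pair, hydroxymethyl had been seen only in compound 3, whose core also carries a different group, so the effect of hydroxymethyl could not be told apart from that other difference; here the rest of the molecule stays the same and the step belongs to the change of acetylsulfanyl to hydroxymethyl alone. Nothing measured here tells why hydroxymethyl gives the lower number on this carbon.

As far as these compounds go, with only acetylsulfanyl and hydroxymethyl compared directly at this position, it remains open how an amine, a carboxylic acid, a methoxymethyl group or a longer chain such as hydroxyethyl would fare there. From the compounds shown here alone, it also remains open whether the same swap would give a step of similar size on other cores, such as that of compound 2.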